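Swapping a pyridine ring for a methylphenyl ring

The compounds below may be only part of what the source reports. "The series", "measured", "known", "first", "only" and "open" are said of these compounds alone.

Compound 1 `CCOc1ncccc1-c1c(C)nn(-c2nc(-c3ccc(Cl)c(Cl)c3)c(SC(C)C)s2)c1C(=O)O` is the starting point. In a functional assay on BJAB cells (Homo sapiens) for antiproliferative activity, with a stated time of 4 days (a lower number here means that less compound is needed, a higher number that more compound is needed for the effect), compound 1 gives 11000 nM. Compound 2 `Cc1nn(-c2nc(-c3ccc(Cl)c(Cl)c3)c(SC(C)C)s2)c(C(=O)O)c1-c1cccnc1` differs from it in one place, and in this assay compound 2 gives 12000 nM. The step of a 1.1-fold higher number from compound 1 to compound 2 (0.04 log units; within the scatter) replaces ethoxy with hydrogen on an aromatic carbon; since that step lies within the scatter, the two numbers cannot be told apart. Within the data shown here, compound 2 therefore stands together with compound 1 as one of two indistinguishable numbers measured so far.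

Compound 3 `Cc1cccc(-c2c(C)nn(-c3nc(-c4ccc(Cl)c(Cl)c4)c(SC(C)C)s3)c2C(=O)O)c1` is not yet measured. Its change from compound 2 is 3-methylphenyl in place of pyridin-3-yl on an aromatic carbon. Among the measured compounds shown here, no measured step touches this position or this kind of exchange, so the only step at hand, which concerned the ethoxy group, offers no direct guidance. With nothing to point either way, the expected step of no change at the digits printed from compound 2 to compound 3 (within the scatter) is none beyond the scatter. Compound 3 is accordingly estimated at 12000 nM, within a range of 4000 nM to 36000 nM, in this assay.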

Compound 3, half-maximal effective concentration: 17000 nM
Compound 3: the middle estimate sits 1.4-fold (0.15 log units) below what was measured, within the range that was stated.
By their numbers in this assay, from the lowest: compounds 1, 2 and 3 (each within the scatter of the next).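

At the carbon that sits next to the ring atom bearing a carboxy group, putting 3-methylphenyl in place of pyridin-3-yl gives in this assay a 1.4-fold higher number from compound 2 to compound 3 (0.15 log units; within the scatter) and so cannot be told apart from no difference at all, even though the ring nitrogen leaves and a methyl group enters. Replacing 2-ethoxypyridin-3-yl at the same carbon gives a 1.5-fold higher number from compound 1 to compound 3 (0.19 log units; within the scatter) and is likewise indistinguishable, so this position has now held a carbon-only aromatic ring as well as two pyridine-based groups with no difference that can be read. No outside measurement bears on this result, and its cause remains unknown.

From the compounds shown here alone, all three groups are six-membered aromatic rings, so it remains open whether a group of another kind at this carbon, such as an amine, a carboxylic acid or a longer alkyl chain, would also stay within the scatter. A plain phenyl ring could also help separate the loss of the ring nitrogen from the gain of the methyl group, two differences that the step to 3-methylphenyl carries together.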